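Chain Extension Between Two Analogues at the Assay Limit

The source may hold more compounds than are shown below. What is called first, only, known or untested is meant among the compounds shown, and "the series" means these compounds.

Compound 1, `CCCCCCCCCCCCCCCCCCOC1(c2ccc(Br)cc2)SC=C(C)n2c1noc2=O`: > 100000 nM
Compound 2, `CCCCCCCCCCCCCCCOC1(c2ccc(Cl)cc2)SC=C(C)n2c1noc2=O`: > 100000 nM

Both measured compounds were tested in a functional assay on A2780 cells (Homo sapiens) for antiproliferative activity, read by MTT assay, with a stated time of 3 days; a lower number here means a stronger inhibitor, a higher number a weaker inhibitor. For compound 1 the result is only a limit of this assay, not a number, namely > 100000 nM. Compound 2 likewise gives only a limit in this assay, > 100000 nM. Compound 2 therefore stands at the upper edge of what this assay reports, and it shares that position with compound 1, since both values sit at the same point: the limit of > 100000 nM in this assay, at which 2 of the 2 values shown sit.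

Compound 3, `CCCCCCCCCCCCCCCCCCOC1(c2ccc(Cl)cc2)SC=C(C)n2c1noc2=O`, is the next member. It differs from compound 2 in one respect: propyl in place of hydrogen on a saturated chain carbon, ten or more bonds along the chain from an oxygen on a saturated carbon. Going by the values given here, no step between measured compounds is available to calibrate such a change. Among the compounds with values here, since compound 2 sits at the limit, and the only other compound, compound 1, also sits at the limit (the limit of > 100000 nM in this assay, at which 2 of the 2 values shown sit), no shift beyond the scatter is expected in this assay. Compound 3 is expected to give 150000 nM, within the range 60000 nM to 400000 nM, most probably again as a limit. The expected step is accordingly a step that the limit leaves unreadable from compound 2 to compound 3, lying within the scatter.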

Compound 3, half-maximal inhibitory concentration: > 100000 nM
Compound 3: only a limit was reported; the forecaster's own chance of this, stated with the estimate: 85%; the middle value is on the limit's open side.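

Compound 3 also returns only a limit, > 100000 nM. No step from compound 2 to compound 3 or from compound 1 to compound 3 can be read, because all three compounds sit at the same point: the limit of > 100000 nM in this assay, at which 3 of the 3 values shown sit.

The compounds shown leave open whether the longer chain, or chloro in place of bromo, changes antiproliferative activity at all.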